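The compounds below may be only part of what the source reports. "The series", "measured", "known", "first", "only" and "open" are said of these compounds alone.

Among the measured compounds shown here, in a functional assay on MGC-803 cells (Homo sapiens) for cytotoxicity, read by MTT assay, with a stated time of 48 h (a lower number here means a stronger inhibitor, a higher number a weaker inhibitor), only one of the three compounds tested so far has yielded a number. Compound 1 (`CC1=NN(C(=O)COc2ccc(Cl)cc2)C(c2ccccc2O)C1`) is recorded as "not active" (no number reported), and compound 2 (`CC1=NN(S(=O)(=O)c2ccc(C)cc2)C(c2cc(Br)cc(Br)c2O)C1`) as "not active" (no number reported). Compound 3 (`O=C(c1ccccc1Cl)N1N=C(c2cc3ccccc3oc2=O)CC1c1ccccc1`) gives 6640 nM, which makes it the only numerical reference point, with no other number to rank it against.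

Compound 4 (`CC(C)CNCC(=O)N1N=C(c2cc3ccccc3oc2=O)CC1c1ccccc1`) keeps the core of compound 3 and changes one piece: (isobutylamino)methyl in place of 2-chlorophenyl on a carbonyl carbon. In words, (isobutylamino)methyl stands in place of 2-chlorophenyl on a carbonyl carbon, whose other neighbour is an amide-type nitrogen in a ring. The entering group has no ring, so this is more than a small edit to the leaving group.

For the measured compounds named here, no two measured compounds differ in just one place, so no measured step shows what a swap like this does. The expectation therefore rests on compound 3 at 6640 nM and carries wide uncertainty. The expected change, a 1.2-fold higher number from compound 3 to compound 4 (0.08 log units; within the scatter), leans slightly towards a weaker inhibitor, with no shift beyond the usual scatter anticipated. A result without a number also remains possible. For compound 4, the estimated value is 8000 nM, within an expected range of 2000 nM to 30000 nM.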

Compound 4, half-maximal inhibitory concentration: 29700 nM
Estimate against measurement, compound 4: 3.7-fold (0.57 log units) below; low and high end bracket the measured number.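

In this assay, among the compounds shown here, putting (isobutylamino)methyl in place of 2-chlorophenyl on the carbonyl carbon gives a 4.5-fold higher number from compound 3 to compound 4 (0.65 log units; beyond the scatter) and provides the first measured step at this place. It shows that the group held on this carbonyl carbon matters: with the rest of the molecule unchanged, the swap moves the result beyond the usual scatter towards a weaker inhibitor. Nothing in the data shown explains the shift.

Compound 4 still gives a number, so this open-chain group does not turn the compound into an entry recorded as "not active", but a single step cannot say which part of the swap matters, as the chlorine, the aromatic ring and the amine nitrogen all change at once. A plain phenyl group on the same carbonyl carbon would isolate the chlorine, while a simple butyl chain with no nitrogen would help separate the effect of losing the ring from that of adding the amine.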